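The source may hold more compounds than are shown below. What is called first, only, known or untested is meant among the compounds shown, and "the series" means these compounds.

Three compounds share one core and differ only in the ring attached to a sulfonyl sulfur. In an assay on HEK293 cells for displacement of a labelled ligand from 5-hydroxytryptamine receptor 6 (Homo sapiens), with a stated time of 60 min, tested at 1 uM, in the presence of a further agent that is not named here (a lower number here means a weaker effect, a higher number a stronger effect of the compound at the concentration tested), compound 1 `COc1cc(N)c(Cl)cc1C(=O)CCC1CCN(CCNS(=O)(=O)c2ccc(N)cc2)CC1` gives 46%, compound 2 `COc1cc(N)c(Cl)cc1C(=O)CCC1CCN(CCNS(=O)(=O)c2cc(Br)ccc2Br)CC1` gives 52%, and compound 3 `COc1ccc(S(=O)(=O)NCCN2CCC(CCC(=O)c3cc(Cl)c(N)cc3OC)CC2)cc1` gives 52%. Compound 3 therefore stands level with compound 2 at the top of these three numbers, while the remaining step is a number 6 percentage points higher from compound 1 to compound 3 (within the scatter).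

Compound 4 `COc1cc(N)c(Cl)cc1C(=O)CCC1CCN(CCNS(=O)(=O)c2ccc(N)c(Br)c2)CC1` differs from compound 3 in one place: 4-amino-3-bromophenyl in place of 4-methoxyphenyl on a sulfonyl sulfur. Going by the values given here, the steps that bear on such a swap at this sulfonyl sulfur are a number 6 percentage points higher from compound 1 to compound 2 (within the scatter) and no change at the digits printed from compound 2 to compound 3 (within the scatter), and neither leaves the scatter. A step of a number 3 percentage points lower from compound 3 to compound 4 (within the scatter) is therefore expected, with no real change. The estimate for compound 4 is 49%, between 38% and 60%.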

Compound 4, a percentage reported as inhibition, at one concentration (the size of the read-out at that concentration, not a potency): 85%
Estimate against measurement, compound 4: 36 percentage points below; measured number above the stated range.
By their numbers in this assay, from the lowest: compounds 1, 2 and 3 (each within the scatter of the next); then compound 4.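

Until now, swapping the ring on the sulfonyl sulfur moved nothing beyond the scatter, but the 4-amino-3-bromophenyl ring gives a number 33 percentage points higher from compound 3 to compound 4 (beyond the scatter) and a number 33 percentage points higher from compound 2 to compound 4 (beyond the scatter). Going by these compounds alone, the clearest comparison is a number 39 percentage points higher from compound 1 to compound 4 (beyond the scatter), where the only change is bromo in place of hydrogen on an aromatic carbon. Bromine alone is not enough, as compound 2 carries two bromo groups without reaching compound 4. From the compounds shown here alone, whether chloro or methyl in place of that bromo would serve as well remains open. Nothing available explains the size of this step.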